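Working notes: from compound 3 to compound 4

The compounds below may be only part of what the source reports. "The series", "measured", "known", "first", "only" and "open" are said of these compounds alone.

Measured so far in a functional assay on U-87MG ATCC cells for antiproliferative activity against U-87 MG (Homo sapiens), read by MTT assay (on this read-out higher numbers stand for weaker inhibition and lower numbers for stronger inhibition), as follows
- compound 1 `Cc1cc(=O)c(O)c(Cc2ccc(F)cc2)o1` gives > 50000 nM as a limit
- compound 2 `Cc1cc(=O)c(O)c(C(c2ccc(OCc3ccccc3)cc2)c2oc(C)cc(=O)c2O)o1` gives 4600 nM as a number
- compound 3 `Cc1cc(=O)c(O)c(C(c2ccc(OCc3ccc([N+](=O)[O-])cc3)cc2)c2oc(C)cc(=O)c2O)o1` gives > 50000 nM as a limit

Compound 3 carries a limit and no number (the limit of > 50000 nM in this assay, at which 2 of the 3 values shown sit). The next compound, compound 4 `Cc1cc(=O)c(O)c(C(c2ccc(CCc3ccccc3)cc2)c2oc(C)cc(=O)c2O)o1`, has phenethyl in place of (4-nitrobenzyl)oxy on an aromatic carbon of a six-membered aromatic ring of carbon only, para to a large group (phenethyl in place of (4-nitrobenzyl)oxy on an aromatic carbon). Among the compounds with values here, one measured step bears on this change: an at least 10-fold higher number from compound 2 to compound 3 (1.03 log units; beyond the scatter) came with nitro in place of hydrogen on an aromatic carbon, a large step beyond the scatter. Compound 4 has no nitro, and neither does compound 2 with its 4600 nM in this assay as the nearest measured number. Within the data shown here, no measured step covers phenethyl itself, so the estimate stays wide. The expected change is a large one towards stronger inhibition, estimated as an at least 6.2-fold lower number from compound 3 to compound 4 (0.79 log units; beyond the scatter) in this assay on this reasoning. For compound 4 the estimate is 8000 nM with an expected range from 2500 nM to 30000 nM and some expected chance that only a limit is reported.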

Compound 4, half-maximal inhibitory concentration: 27200 nM
Estimate against measurement, compound 4: 3.4-fold (0.53 log units) below; low and high end bracket the measured number.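

In this assay, phenethyl in place of benzyloxy on the aromatic carbon, para to a large group, gives a 5.9-fold higher number from compound 2 to compound 4 (0.77 log units; beyond the scatter). Within the data shown here, this is the first measured change to the group at this place other than the added nitro, and it shows that a compound without benzyloxy can still return a number, though a weaker one than compound 2 gives. Phenethyl in place of (4-nitrobenzyl)oxy gives an at least 1.8-fold lower number from compound 3 to compound 4 (0.26 log units; that floor lies within the scatter), and this step can be read only as a floor, which lies within the scatter, because compound 3 stands at a limit: the limit of > 50000 nM in this assay, at which 2 of the 4 values shown sit.

The compounds shown leave open how much of the difference between benzyloxy and phenethyl belongs to the linking atoms and how much to the chain as a whole, which an amine or amide link of the same length, or a longer chain, would help to separate. They also leave open whether the weakening seen with nitro extends to other groups at that place, such as a methoxy, an amine or a carboxylic acid.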